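This account rests on a few compounds, and the source may have more. Where it says the series, first, only, none or still open, it means among the compounds named here.

Measured so far in a functional assay on COLO 205 cells (Homo sapiens) for inhibition, read by sulforhodamine B assay, with a stated time of 48 h, tested at 0.1 uM; on this read-out higher numbers stand for a weaker effect at the one concentration tested and lower numbers for a stronger effect:
compound 1 `COc1cc(Cl)cc(-c2nn(-c3cccc(NC(=O)Nc4ccc(Cl)c(C(F)(F)F)c4)c3)cc2-c2ccncc2)c1` — 99%
compound 2 `COc1cc(Cl)cc(-c2nn(-c3cccc(NC(=O)Nc4cc(C(F)(F)F)cc(C(F)(F)F)c4)c3)cc2-c2ccncc2)c1` — 98%
compound 3 `COc1cc(Cl)cc(-c2nn(-c3cccc(NC(=O)Nc4ccc(Cl)c(Cl)c4)c3)cc2-c2ccncc2)c1` — 103%

Compound 3 stands with the highest of the three numbers in this assay, yet its gap to compound 1 and to compound 2 is within the scatter, so no ordering among the three can be claimed. Among the compounds with values here, the one measured step, a number 4 percentage points higher from compound 1 to compound 3 (within the scatter), is likewise within the scatter.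

Compound 4 `COc1cc(Cl)cc(-c2nn(-c3cccc(NC(=O)Nc4cccc(C(F)(F)F)c4)c3)cc2-c2ccncc2)c1` differs from compound 3 by 3-(trifluoromethyl)phenyl in place of 3,4-dichlorophenyl on an amide-type nitrogen. Within the data shown here, no measured step covers exactly this change; the nearest is the step from compound 1 to compound 3, which was within the scatter, and compound 2 with its two trifluoromethyl groups sits within the scatter of both. All three numbers are near the top of the read-out scale at the single concentration tested.

It is therefore expected that compound 4 shows a number 4 percentage points lower from compound 3 to compound 4 (within the scatter), no step beyond the scatter, and compound 4 is estimated at 99% with a range from 88% to 108%.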

Compound 4, a percentage reported as activity, at one concentration (the size of the read-out at that concentration, not a potency): 101%
Estimate against measurement, compound 4: 2 percentage points below; the measured number falls inside the stated range.
By their numbers in this assay, from the lowest: compounds 2, 1, 4 and 3 (each within the scatter of the next).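

In this assay the change at the amide-type nitrogen, 3-(trifluoromethyl)phenyl in place of 3,4-dichlorophenyl, gives a number 2 percentage points lower from compound 3 to compound 4 (within the scatter) and no readable change. Hydrogen in place of chloro gives a number 2 percentage points higher from compound 1 to compound 4 (within the scatter) on this ring, and hydrogen in place of trifluoromethyl gives a number 3 percentage points higher from compound 2 to compound 4 (within the scatter) on it too, so a single trifluoromethyl group reads the same here as the more heavily substituted rings. Nothing at hand explains this flat picture at this position.

From the compounds shown here alone, what a carboxylic acid or a dimethylamino group on this ring would do remains open, as does replacing the ring with a longer alkyl chain. Also open, going by these compounds, is whether these four compounds separate at a higher concentration, as each number comes from a single concentration and all sit near the top of the scale.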